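The source may report more compounds than this note shows. Statements on the series, on what has been measured and on what is new or still open speak of the compounds shown alone.

In a functional assay on SNB-19 cells (Homo sapiens) for cytotoxicity, read by sulforhodamine B assay, with a stated time of 48 h (a higher number here means a weaker inhibitor of growth, a lower number a stronger inhibitor of growth), compound 3 `ClCc1cccc(Cn2cnc3c(Cl)nc(Cl)nc32)c1` gives 4160 nM, while compound 1 `ClCc1cccc(Cn2cnc3c(Cl)ncnc32)c1` gives 12600 nM. The two differ by hydrogen in place of chloro on an aromatic carbon, and that change brings a 3.0-fold higher number from compound 3 to compound 1 (0.48 log units; beyond the scatter). Compound 2 `ClCc1ccc(Cn2cnc3nc(Cl)nc(Cl)c32)cc1` carries the same atoms as compound 3 joined differently; how the two cores differ is not broken down here. In this assay compound 2 gives only a limit, > 100000 nM, which sits at the limit of > 100000 nM in this assay, at which 1 of the 3 values shown sits. Compound 4 `ClCc1ccc(Cn2cnc3ncnc(Cl)c32)cc1` has not yet been measured in this assay. Within the data shown here, it differs from compound 2 by hydrogen in place of chloro on an aromatic carbon, the same change as the one from compound 3 to compound 1. Because the earlier change gave a 3.0-fold higher number from compound 3 to compound 1 (0.48 log units; beyond the scatter), the expected step here is a step that the limit leaves unreadable from compound 2 to compound 4. Compound 4 is therefore expected to be reported as a limit as well, with an estimate of 150000 nM and a likely range from 60000 nM to 400000 nM.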

Compound 4, concentration for total growth inhibition: 3160 nM
For compound 4 the middle estimate is 47-fold (1.68 log units) above the measured one, and the stated range ends above it.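

On the core of compound 2, hydrogen in place of chloro brings an at least 31-fold lower number from compound 2 to compound 4 (1.50 log units; beyond the scatter), whereas on the core of compound 3 it brings a 3.0-fold higher number from compound 3 to compound 1 (0.48 log units; beyond the scatter). In this assay the change therefore does not carry from one core to the other, not even in direction: the same change on two cores in this assay, a 3.0-fold higher number (0.48 log units; beyond the scatter) from compound 3 to compound 1 and an at least 31-fold lower number (1.50 log units; beyond the scatter) from compound 2 to compound 4, at least 95-fold (1.98 log units) apart, beyond the scatter of two such steps The value of compound 2 is a limit, > 100000 nM, so the full size of its step stays unknown, and two pairs alone do not show why the cores part.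

The compounds shown leave open how each core responds when an amine or a methoxy group takes the place of that chloro. They also leave open whether the split between the cores would persist with such groups.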